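Aryl exchange on the shared core: compound 3 to compound 4

The compounds below may be only part of what the source reports. "The series", "measured", "known", "first", "only" and "open" are said of these compounds alone.

Measured so far in a functional assay on B16-F10 cells (Mus musculus) for cytotoxicity; on this read-out lower numbers stand for stronger inhibition and higher numbers for weaker inhibition:
compound 1 `O=c1oc2ccccc2c2nc3c(ccc4cc[nH]c43)c(-c3ccc(F)cc3)c12`: 70700 nM
compound 2 `O=c1oc2ccccc2c2nc3c(ccc4cc[nH]c43)c(-c3ccccn3)c12`: 70700 nM
compound 3 `O=c1oc2ccccc2c2nc3c(ccc4cc[nH]c43)c(-c3cccc4ccccc34)c12`: 70700 nM

Compound 3 stands level with compounds 1 and 2 on the numbers shown; its nearest neighbour is compound 1 and its furthest is compound 2, and neither gap reaches beyond the scatter. The three exchanges of the aryl group on the shared core were all flat: no change at the digits printed from compound 1 to compound 2 (within the scatter), no change at the digits printed from compound 1 to compound 3 (within the scatter) and no change at the digits printed from compound 2 to compound 3 (within the scatter). Whatever is placed on that aromatic carbon of compound 3 has, so far, left the read-out of this assay unmoved.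

Compound 4 `O=c1oc2ccccc2c2nc3c(ccc4cc[nH]c43)c(-c3ccccc3)c12` differs from compound 3 in one place: phenyl in place of naphthalen-1-yl on an aromatic carbon. Among the measured compounds shown here, the steps that bear on this change are no change at the digits printed from compound 1 to compound 3 (within the scatter) and no change at the digits printed from compound 2 to compound 3 (within the scatter), which both bring naphthalen-1-yl onto the same aromatic carbon and show no change; removing its second ring to give phenyl is expected to behave the same way. For compound 4 the step of no change at the digits printed from compound 3 to compound 4 (within the scatter) is therefore expected to stay within the scatter, in no particular direction. Compound 4 is estimated at 70700 nM in this assay, within a range of 35000 nM to 141000 nM.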

Compound 4, half-maximal inhibitory concentration: 70700 nM
Beside the measured number, compound 4's estimate shows no gap at the digits printed; low and high end bracket the measured number.
By their numbers in this assay, from the lowest: compounds 1, 2, 3 and 4 (each within the scatter of the next).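

In this assay, phenyl adds the unsubstituted ring to the set at this aromatic carbon, opposite the ring nitrogen, and the reading from naphthalen-1-yl is no change at the digits printed from compound 3 to compound 4 (within the scatter). The second ring of naphthalen-1-yl is therefore not needed to hold the read-out at this level, and the comparison with pyridin-2-yl, no change at the digits printed from compound 2 to compound 4 (within the scatter), shows the same for the exchange of that ring for an all-carbon one; hydrogen in place of fluoro gives no change at the digits printed from compound 1 to compound 4 (within the scatter), so the fluoro group of compound 1 also leaves the read-out unmoved. No measured evidence is available to account for this flat behaviour across the four aryl groups.

Going by these compounds, all four compounds carry an aromatic ring on this carbon, so it remains open whether an amine, a carboxylic acid or a longer alkyl chain there would shift the read-out. Among the compounds shown here, also open is whether any change elsewhere on the shared core would move this assay away from the single value shared by these compounds.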